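Moving a chlorine around a ring on a weak acyltransferase inhibitor

The compounds below may be only part of what the source reports. "The series", "measured", "known", "first", "only" and "open" are said of these compounds alone.

Three compounds share one core: a long sulfonamide chain, a carboxylic acid and an attached aryl ring. Compound 1 `CCCCCCCCS(=O)(=O)Nc1cc(-c2ccccc2-c2ccccc2)ccc1C(=O)O` carries an ortho-phenyl group on that ring, compound 2 `CCCCCCCCS(=O)(=O)Nc1cc(-c2ccc(OC)cc2)ccc1C(=O)O` a methoxyphenyl, and compound 3 `CCCCCCCCS(=O)(=O)Nc1ccc(-c2ccccc2Cl)cc1C(=O)O` a 2-chlorophenyl. In an assay on mitochondria (strain BALB/c) for inhibition of glycerol-3-phosphate acyltransferase 1, mitochondrial (Mus musculus), read by scintillation counting, with a stated time of 10 min (on this read-out higher numbers stand for weaker inhibition and lower numbers for stronger inhibition), compound 1 gives 17100 nM, compound 2 gives 13300 nM and compound 3 gives 14400 nM. The number for compound 3 is the second highest of the three, yet the gaps to compound 2 and to compound 1 both lie within the scatter, so these three cannot be told apart.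

Compound 4 `CCCCCCCCS(=O)(=O)Nc1ccc(-c2ccc(Cl)cc2)cc1C(=O)O` has not been measured. It differs from compound 3 in one place: 4-chlorophenyl in place of 2-chlorophenyl on an aromatic carbon. The same atoms are present, only joined differently. Among the measured compounds shown here, no step between measured compounds tests this kind of change on its own, so there is nothing to lean on beyond the fact that the three measured compounds, with different groups in this region, all give similar numbers in this assay. The expectation is therefore a step of about a 1.0-fold lower number from compound 3 to compound 4 (0.01 log units; within the scatter), meaning no change beyond the scatter. Compound 4 is estimated at 14000 nM, with a range from 6000 nM to 35000 nM.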

Compound 4, half-maximal inhibitory concentration: 9200 nM
Compound 4: the middle estimate sits 1.5-fold (0.18 log units) above what was measured; the measured number falls inside the stated range.
By their numbers in this assay, from the lowest: compounds 4, 2, 3 and 1 (each within the scatter of the next).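

Among the compounds shown here, replacing 2-chlorophenyl with 4-chlorophenyl is the first change here that can be read on its own, and it gives a 1.6-fold lower number from compound 3 to compound 4 (0.19 log units; within the scatter) in this assay. The earlier compounds shown here differ from one another in more than one place. The ring carries the same atoms in both compounds, so this pair isolates where the chlorine sits, and for these two placements that difference does not separate the compounds beyond the usual scatter of repeated measurements. Nothing available explains the size of this step or shows how the chlorine's placement acts on the enzyme.

This single pair says nothing about whether a different group on the same ring, such as an amine, a nitrile or a second carboxylic acid, would produce a step beyond the scatter. It also leaves open how much the rest of the shared core contributes, for example whether a shorter chain on the sulfonamide or an amide in place of the carboxylic acid would give a clearly different number in this assay.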